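The source may hold more compounds than are shown below. What is called first, only, known or untested is meant among the compounds shown, and "the series" means these compounds.

Measured in a functional assay on HUVEC cells (Homo sapiens), read by scintillation counting and thymidine incorporation, with a stated time of 24 h; on this read-out lower numbers stand for stronger inhibition and higher numbers for weaker inhibition:

- Compound 1 `CCC(C)n1ncn(-c2ccc(N3CCN(c4ccc(OC[C@@H]5CO[C@@](CC)(c6ccc(Cl)cc6Cl)O5)cc4)CC3)cc2)c1=O`: 353 nM
- Compound 2 `CCC(C)n1ncn(-c2ccc(N3CCN(c4ccc(OC[C@@H]5CO[C@@](Cn6cnc(C)n6)(c6ccc(Cl)cc6Cl)O5)cc4)CC3)cc2)c1=O`: 272 nM
- Compound 3 `CCC(C)n1ncn(-c2ccc(N3CCN(c4ccc(OC[C@@H]5CO[C@@](Cn6cc(C(F)(F)F)nc6C)(c6ccc(Cl)cc6Cl)O5)cc4)CC3)cc2)c1=O`: 441 nM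

These three compounds share one core and differ only in the group on a saturated chain carbon bound to a saturated ring carbon. Compound 3, at 441 nM, does not stand apart from the other two. Both a 1.2-fold higher number from compound 1 to compound 3 (0.10 log units; within the scatter) and a 1.6-fold higher number from compound 2 to compound 3 (0.21 log units; within the scatter) are no larger than the differences expected between repeated measurements of a single compound.

The next compound, compound 4 `CCC(C)n1ncn(-c2ccc(N3CCN(c4ccc(OC[C@@H]5CO[C@@](Cn6nnnc6C)(c6ccc(Cl)cc6Cl)O5)cc4)CC3)cc2)c1=O`, keeps the core and alters that same group. The change is 5-methyl-1H-tetrazol-1-yl in place of 2-methyl-4-(trifluoromethyl)-1H-imidazol-1-yl on a saturated chain carbon bound to a saturated ring carbon. In words, 5-methyl-1H-tetrazol-1-yl takes the place of 2-methyl-4-(trifluoromethyl)-1H-imidazol-1-yl.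

All three measured steps swap the group at this same place, so all of them bear on the new change. Besides the two already given, there is a 1.3-fold lower number from compound 1 to compound 2 (0.11 log units; within the scatter). Among the measured compounds shown here, none of them goes beyond the scatter, although no measured compound yet carries the tetrazolyl group. No step beyond the scatter is therefore expected in this assay. The estimated change is a 1.4-fold lower number from compound 3 to compound 4 (0.14 log units; within the scatter), and it is expected to be too small to distinguish from the scatter. For compound 4 the expected value is 320 nM, with an estimated range of 160 nM to 650 nM.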

Compound 4, half-maximal inhibitory concentration: 101 nM
Compound 4: middle estimate off by 3.2-fold (0.50 log units), on the high side; the measured number lies below the stated range.
By their numbers in this assay, from the lowest: compound 4; then compounds 2, 1 and 3 (each within the scatter of the next).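

Until now, changing the group on a saturated chain carbon bound to a saturated ring carbon had left the number in this assay within the scatter, so this position could have seemed indifferent to what it carries. With 5-methyl-1H-tetrazol-1-yl there is a 4.4-fold lower number from compound 3 to compound 4 (0.64 log units; beyond the scatter) and a 2.7-fold lower number from compound 2 to compound 4 (0.43 log units; beyond the scatter) and a 3.5-fold lower number from compound 1 to compound 4 (0.54 log units; beyond the scatter) as well, so compound 4 stands apart from all three earlier compounds by modest steps beyond the scatter, and the position does respond to the group placed there. A five-membered aromatic ring alone does not account for this, since compound 2 and compound 3 also carry one and stay within the scatter of compound 1, and no measurement here explains why the tetrazolyl group behaves differently.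

The compounds shown leave open whether the lower number goes with the tetrazole ring or with its methyl group, a question that 1H-tetrazol-1-yl without the methyl, or 5-ethyl-1H-tetrazol-1-yl, would address. Also open, on these data alone, is how a group without an aromatic ring at this place, such as an amine or a carboxylic acid on the same chain carbon, would compare.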